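Chloro on the Carbon Ring: Expecting Compound 4

This account rests on a few compounds, and the source may have more. Where it says the series, first, only, none or still open, it means among the compounds named here.

Measured so far:
- compound 1 `O=c1c(SC(=S)N2CCCCC2)coc2ccccc12` gives 7800 nM
- compound 2 `O=c1cc(CSC(=S)N2CCCCC2)oc2ccccc12` gives only a limit of the assay, > 25000 nM
- compound 3 `O=c1c(Cl)c(CSC(=S)N2CCCCC2)oc2ccccc12` gives 3300 nM

All three were tested in a functional assay on LM7 cells (Homo sapiens) for antiproliferative activity, read by MTT assay, with a stated time of 72 h; on this read-out higher numbers stand for weaker inhibition and lower numbers for stronger inhibition. Compound 1 stands highest of the two real numbers, and compound 3 lies nearest to it. Compound 2 and compound 3 differ in one place: chloro in place of hydrogen on an aromatic carbon. This change gave an at least 7.5-fold lower number from compound 2 to compound 3 (0.87 log units; beyond the scatter). That this step is known only as a lower bound is because of the limit of > 25000 nM in this assay, at which 1 of the 3 values shown sits.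

Compound 4 `O=c1c(SC(=S)N2CCCCC2)coc2ccc(Cl)cc12` has not been measured. It differs from compound 1 in one place: chloro in place of hydrogen on an aromatic carbon. The difference between the core of compound 1 and the core of compound 2 is not broken down here. The two chloro placements are not the same: in the step from compound 2 to compound 3 the chloro enters a six-membered aromatic ring with 1 oxygen, ortho to a group of 1 heavy atom, ortho to a large group, two atoms from the ring oxygen, whereas in compound 4 it enters a six-membered aromatic ring of carbon only. So this is the same kind of change, not the same change.

From compound 1 to compound 4 a step of a 2.2-fold lower number from compound 1 to compound 4 (0.35 log units; beyond the scatter) is expected, resting on an at least 7.5-fold lower number from compound 2 to compound 3 (0.87 log units; beyond the scatter) but tempered by the different surroundings. Compound 4 is estimated at 3500 nM, likely between 1200 nM and 10000 nM.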

Compound 4, half-maximal inhibitory concentration: > 25000 nM
Compound 4: a limit, no number; the forecaster's own chance of this, stated with the estimate: 3%; at least 7.1-fold (0.85 log units) between middle value and limit.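

In this assay compound 4 gives > 25000 nM, which is a limit of the assay and not a number. Chloro in place of hydrogen on the carbon ring gave an at least 3.2-fold higher number from compound 1 to compound 4 (0.50 log units; beyond the scatter), whereas the same kind of change on the other core went the opposite way, so in this series the change cannot be carried from one core to another as a fixed gain: the same change on two cores in this assay, an at least 7.5-fold lower number (0.87 log units; beyond the scatter) from compound 2 to compound 3 and an at least 3.2-fold higher number (0.50 log units; beyond the scatter) from compound 1 to compound 4, at least 24-fold (1.38 log units) apart, beyond the scatter of two such steps This does not show how large the step to compound 4 really is, nor whether the place of the chloro or the rest of the core sets the direction, and the size stays unknown because only a bound is available: the limit of > 25000 nM in this assay, at which 2 of the 4 values shown sit.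

The compounds shown leave open whether a chloro on the carbon ring of the core of compound 2 would follow compound 4 or compound 3, which would help separate the place of the chloro from the core. They also leave open whether a fluoro or a methoxy group in the place of the chloro of compound 4 would give a real number in this assay or would also stop at the limit.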